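A few compounds are considered here, and "the series" means these few. Any claim that something is new, unique, unknown or untested is made for them only; others in the source may bear on it.

Measured in a functional assay on A549 cells (Homo sapiens) for antiproliferative activity, read by MTT assay, with a stated time of 72 h; on this read-out lower numbers stand for stronger inhibition and higher numbers for weaker inhibition:
compound 1, `COc1cc(F)c(NC(=O)c2ccnc(O)c2)cc1Nc1nccc(-c2cn(C)c3ccccc23)n1`, gives 11700 nM;
compound 2, `COc1cc(N(C)CCN(C)C)c(NC(=O)c2ccncc2)cc1Nc1nccc(-c2cn(C)c3ccccc23)n1`, gives 10400 nM;
compound 3, `COc1cc(N(C)CCN(C)C)c(NC(=O)c2ccnc(O)c2)cc1Nc1nccc(-c2cn(C)c3ccccc23)n1`, gives 11200 nM.

Compound 3 stands second highest of these three numbers, though all three sit within the scatter of one another: the change from compound 1 to compound 3 gives a 1.0-fold lower number from compound 1 to compound 3 (0.02 log units; within the scatter), and that from compound 2 to compound 3 gives a 1.1-fold higher number from compound 2 to compound 3 (0.03 log units; within the scatter). Compound 4, `COc1cc(N(C)CCN(C)C)c(NC(=O)c2cccnc2)cc1Nc1nccc(-c2cn(C)c3ccccc23)n1`, differs from compound 3 by pyridin-3-yl in place of 2-hydroxypyridin-4-yl on a carbonyl carbon. Going by the values given here, of the measured steps, only the one from compound 2 to compound 3 touches this change, and it stayed within the scatter. The step from compound 3 to compound 4 is therefore expected to be a 1.0-fold lower number from compound 3 to compound 4 (0.01 log units; within the scatter), with no shift beyond the scatter anticipated. Compound 4 is estimated at 11000 nM, in the range 5000 nM to 25000 nM.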

Compound 4, half-maximal inhibitory concentration: 1600 nM
Beside the measured number, compound 4's estimate is 6.9-fold (0.84 log units) above it, outside the stated range (below it).
By their numbers in this assay, from the lowest: compound 4; then compounds 2, 3 and 1 (each within the scatter of the next).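

On the carbonyl carbon, pyridin-3-yl gives a 7.0-fold lower number from compound 3 to compound 4 (0.85 log units; beyond the scatter) in this assay when it replaces 2-hydroxypyridin-4-yl and a 6.5-fold lower number from compound 2 to compound 4 (0.81 log units; beyond the scatter) when it replaces pyridin-4-yl, so this position does respond, which the step adding hydroxy alone had not shown. The gain goes with pyridin-3-yl, since the two groups it replaces lie within the scatter of each other. Nothing available here accounts for the shift.

Going by these compounds, whether pyridin-2-yl, phenyl or an amine-bearing pyridin-3-yl would keep this level stays open. So does whether the gain would hold with fluoro in place of the (2-(dimethylamino)ethyl)(methyl)amino group.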